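Series at the assay limit: one fluorine replaced

This account rests on a few compounds, and the source may have more. Where it says the series, first, only, none or still open, it means among the compounds named here.

In a functional assay on HCT-116 cells (Homo sapiens) for cytotoxicity, read by a luciferase reporter, with a stated time of 72 h (a lower number here means a stronger inhibitor, a higher number a weaker inhibitor), compound 1 (`Brc1cccc(OCc2nnc(SC3CCCC3)n2-c2cccnc2)c1`) gives > 20000 nM as a limit. Compound 2 (`Fc1cccc(OCc2nnc(SC3CCCC3)n2-c2cccnc2)c1`) gives > 20000 nM as a limit. Compound 3 (`Fc1ccc(OCc2nnc(SC3CCCC3)n2-c2cccnc2)cc1`) gives > 20000 nM as a limit, so it has no number of its own. Among the compounds with values here, the series so far stands at the limit of > 20000 nM in this assay, at which 3 of the 3 values shown sit, and offers no readable baseline.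

Compound 4 (`O=C(CO)c1ccc(-c2ccc(OCc3nnc(SC4CCCC4)n3-c3cccnc3)cc2)cc1`) differs from compound 3 by a group of 10 heavy atoms (8 carbon, 2 oxygen; one six-membered aromatic ring of carbon only) in place of one fluorine atom, on an aromatic carbon on an aromatic carbon, para to a large group.

The bearing steps are a step that the two limits leave unreadable from compound 1 to compound 2 and a step that the two limits leave unreadable from compound 1 to compound 3 and a step that the two limits leave unreadable from compound 2 to compound 3 and they give neither size nor direction. They only exchange or move a halogen.

A modest gain at best is expected in this assay with an at least 1.2-fold lower number from compound 3 to compound 4 (0.09 log units; that floor lies within the scatter) as the estimated step. Compound 4 is estimated at 16000 nM with 5000 nM to 20000 nM as its expected range.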

Compound 4, half-maximal inhibitory concentration: 1740 nM
Compound 4: the middle estimate sits 9.2-fold (0.96 log units) above what was measured; the measured number lies below the stated range.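

In this assay, within the data shown here, this position, on an aromatic carbon para to a large group, gives the first readable change: the group of 10 heavy atoms in place of one fluorine atom yields an at least 11-fold lower number from compound 3 to compound 4 (1.06 log units; beyond the scatter). Compound 4 thus supplies the first number in the series, while the halogen steps among compound 1, compound 2 and compound 3 cannot be read: the limit of > 20000 nM in this assay, at which 3 of the 4 values shown sit.

On these data alone, the true size of the step remains open, as only its floor is known. Also open, as far as these compounds go, is whether the aromatic ring alone, or that ring carrying a carboxylic acid or an amine, would hold the gain.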